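This account rests on a few compounds, and the source may have more. Where it says the series, first, only, none or still open, it means among the compounds named here.

Compound 1 `O=c1cc(N2CCNCC2)oc2ccccc12`: 56000 nM
Compound 2 `CCCCOc1ccc2c(N3CCNCC3)cc(=O)oc2c1C`: 2790 nM
Compound 3 `O=c1cc(N2CCNCC2)c2cc(OCc3cccnc3)ccc2o1`: 38000 nM

In a functional assay on a cell-free system (plasma, Homo sapiens) for inhibition, with Plasma (Rattus norvegicus) as the target (a lower number here means a stronger inhibitor, a higher number a weaker inhibitor), compound 2 gives the lowest number, 2790 nM, which makes it the strongest inhibitor of the three. Compound 3 and compound 1 both lie above it, beyond the usual scatter.

Compound 4 `Cc1c(OCC2CCCN(C)C2)ccc2c(N3CCNCC3)cc(=O)oc12` alters compound 2 in one place: 1-methylpiperidin-3-yl in place of propyl on a saturated chain carbon bound to an oxygen on an aromatic ring. Butoxy thus becomes (1-methylpiperidin-3-yl)methoxy. Among the measured compounds shown here, no measured pair shows what a change of this kind does, so the expectation stays anchored on compound 2 at 2790 nM. A small loss is expected, and the estimated step of a 1.3-fold higher number from compound 2 to compound 4 (0.10 log units; within the scatter) would remain within the scatter. For compound 4 the estimated value is 3500 nM, with an expected range of 1000 nM to 12000 nM.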

Compound 4, half-maximal inhibitory concentration: 4700 nM
Beside the measured number, compound 4's estimate is 1.3-fold (0.13 log units) below it, within the range that was stated.
By their numbers in this assay, from the lowest: compounds 2 and 4 (each within the scatter of the next); then compounds 3 and 1 (each within the scatter of the next).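

In this assay, replacing butoxy with (1-methylpiperidin-3-yl)methoxy gives a 1.7-fold higher number from compound 2 to compound 4 (0.23 log units; within the scatter). This oxygen on the aromatic ring can therefore carry a saturated chain ending in a six-membered ring with a nitrogen, and the result cannot be told apart from that of the plain butyl chain. Nothing available explains this tolerance. Still open, going by these compounds, is whether a carboxylic acid or a simple open-chain amine in the same place would also stay within the scatter of compound 2. A longer chain than butyl is equally untested in the compounds shown.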